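From a Hydroxyalkyl Chain to a Benzyl Group

The source may hold more compounds than are shown below. What is called first, only, known or untested is meant among the compounds shown, and "the series" means these compounds.

Compound 1 `C=CCn1c(=O)n(CCCCO)c2nc(N)nc(O)c21`: 12%
Compound 2 `C=CCn1/c(=N\C#N)n([C@H]2OC(CO)[C@@H](O)[C@H]2O)c2cc(N)nc(O)c21`: 85%
Compound 3 `Nc1nc(O)c2c(n1)n(C1OC(CO)[C@@H](O)[C@H]1O)c(=O)n2CC(O)CSc1ccccc1`: 12%

In a functional assay on the whole organism (B cells) with Mus musculus as the target (on this read-out higher numbers stand for larger maximal responses and lower numbers for smaller maximal responses), compound 1 gives 12%, which is level with compound 3 within the scatter, and the two together form the low end of the three measured numbers. Compound 2 stands far higher, with 85%, a gap well beyond the scatter. Compound 4 `C=CCn1c(=O)n(Cc2ccccc2)c2nc(N)nc(O)c21` has not yet been measured. It differs from compound 1 by phenyl in place of 3-hydroxypropyl on a saturated chain carbon bound to an aromatic nitrogen. Going by the values given here, no measured pair shows this change, so its effect is unknown; a small step in this assay is expected, upward if anything, because compound 1 already sits at 12% and little room lies below it. The step is expected to be a number 8 percentage points higher from compound 1 to compound 4 (within the scatter). Compound 4 is estimated at 20%, in a range from 5% to 45%.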

Compound 4, largest response reached (reported as maximal response), in percent of the reference or control that the assay uses: 25%
Beside the measured number, compound 4's estimate is 5 percentage points below it, within the range that was stated.
By their numbers in this assay, from the lowest: compounds 1 and 3 (each within the scatter of the next); then compound 4; then compound 2.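

In this assay, phenyl in place of 3-hydroxypropyl gives a modest rise, a number 13 percentage points higher from compound 1 to compound 4 (beyond the scatter). Going by these compounds alone, this is the first measured pair to show that the response can shift with a change at this place, on a saturated chain carbon bound to an aromatic nitrogen. No available measurement accounts for the rise. Going by these compounds, it remains open whether the step follows the entering aromatic ring or the departing hydroxyl, and how an amine, a carboxylic acid or a longer chain ending in phenyl would read at this place.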